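From (4-methoxybenzyl)amino to acetamido on the shared core

A few compounds are considered here, and "the series" means these few. Any claim that something is new, unique, unknown or untested is made for them only; others in the source may bear on it.

In a functional assay on PC-3 cells (Homo sapiens) for antiproliferative activity, read by sulforhodamine B assay, with a stated time of 72 h (a higher number here means a weaker inhibitor, a lower number a stronger inhibitor), compound 1 `COc1ncc(-c2ccc3ncc(NCc4ccccc4)c(OC)c3c2)cc1NS(=O)(=O)c1ccc(F)cc1F` gives 4320 nM. Going by the values given here, in the same test, compound 2 `COc1ccc(CNc2cnc3ccc(-c4cnc(OC)c(NS(=O)(=O)c5ccc(F)cc5F)c4)cc3c2OC)cc1` gives 4520 nM, which places it level with compound 1, the only other measured compound. Compound 3 `COc1ncc(-c2ccc3ncc(NC(C)=O)c(OC)c3c2)cc1NS(=O)(=O)c1ccc(F)cc1F` carries a larger change: acetyl in place of 4-methoxybenzyl on a nitrogen on an aromatic ring. The group on the shared core thus reads acetamido instead of (4-methoxybenzyl)amino.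

Among the compounds with values here, only one measured step bears on this, and only weakly. That step, a 1.0-fold higher number from compound 1 to compound 2 (0.02 log units; within the scatter), is methoxy in place of hydrogen on an aromatic carbon. Within the data shown here, it altered the group that now leaves but did not remove it, and no measured compound lacks that group. The data therefore give no direct size for this change. A moderate move to a lower number is expected in this assay, on thin evidence and with a wide margin in either direction. The estimated step is a 3.0-fold lower number from compound 2 to compound 3 (0.48 log units; beyond the scatter). Compound 3 is expected at 1500 nM, with an estimated range of 200 nM to 8000 nM.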

Compound 3, half-maximal inhibitory concentration: 1240 nM
The estimate for compound 3 lay 1.2-fold (0.08 log units) above the measured number, and the stated range covers the measured number.
By their numbers in this assay, from the lowest: compound 3; then compounds 1 and 2 (each within the scatter of the next).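

In this assay, replacing 4-methoxybenzyl with acetyl gave a 3.6-fold lower number from compound 2 to compound 3 (0.56 log units; beyond the scatter), and replacing benzyl with acetyl gave a 3.5-fold lower number from compound 1 to compound 3 (0.54 log units; beyond the scatter), so both measured routes to the acetamido compound end at a modest gain beyond the scatter. Going by these compounds alone, the substituent on this nitrogen therefore does affect the read-out, which the earlier compounds could not show, as their only step altered the departing group without removing it and stayed within the scatter. Compound 3 now has the lowest number of the three, but nothing measured on these compounds accounts for the difference.

The change removes an aromatic ring and brings in a carbonyl at the same time, and the compounds shown leave these two parts of the change unseparated: a benzoyl group would keep both the ring and the carbonyl, while an ethyl group would have neither. They also leave open how a free amine at this position would compare, and whether a longer acyl chain such as propionyl or butyryl would move the number further in either direction.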